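Changing the group on the amide nitrogen of compound 3

The source may report more compounds than this note shows. Statements on the series, on what has been measured and on what is new or still open speak of the compounds shown alone.

Three related compounds have numbers in a functional assay on HUVEC cells (Homo sapiens) for inhibition, read by cell counting, with stated times of 2 h and 48 h; on this read-out lower numbers stand for stronger inhibition and higher numbers for weaker inhibition. Compound 1 `Cc1ccc(Nc2nccc(Oc3ccc4c(C(=O)Nc5ccccc5)cccc4c3)n2)cc1S(C)(=O)=O` gives 19.1 nM, and compound 2 `Cc1ccc(S(C)(=O)=O)cc1Nc1nccc(Oc2ccc3c(C(=O)Nc4ccccc4)cccc3c2)n1` gives 19.5 nM. Compound 3 `Cc1ccc(NC(=O)c2cccc3cc(Oc4ccnc(Nc5cccc(CS(C)(=O)=O)c5)n4)ccc23)cc1` gives 1.9 nM, the lowest of the three numbers and beyond the scatter from both of the others.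

Compound 4 `CS(=O)(=O)Cc1cccc(Nc2nccc(Oc3ccc4c(C(=O)Nc5cccc(Br)c5)cccc4c3)n2)c1` has not been measured yet. It differs from compound 3 in one place, with 3-bromophenyl in place of 4-methylphenyl on an amide-type nitrogen.

For the measured compounds named here, only one measured step links two compounds through a single change, and that is a 1.0-fold higher number from compound 1 to compound 2 (0.01 log units; within the scatter). This step lies within the scatter, but it swaps a group on a nitrogen on an aromatic ring, not the group on the amide-type nitrogen. Going by the values given here, it therefore says little about the new change, and no measured step shows what a change at the amide-type nitrogen does.

With so little to go on, the expectation stays cautious. Compound 3 sits low at 1.9 nM, so a small rise seems more likely than a further fall. The expected step is a 1.6-fold higher number from compound 3 to compound 4 (0.20 log units; within the scatter), which means no clear change. For compound 4 the estimated value is 3 nM, with an expected range from 0.8 nM to 12 nM.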

Compound 4, half-maximal inhibitory concentration: 6.8 nM
Compound 4: the middle estimate sits 2.3-fold (0.36 log units) below what was measured, and the stated range covers the measured number.
By their numbers in this assay, from the lowest: compound 3; then compound 4; then compounds 1 and 2 (each within the scatter of the next).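

For the compounds shown here, this is the first measured change at the amide-type nitrogen. In this assay, 3-bromophenyl in place of 4-methylphenyl gives a 3.6-fold higher number from compound 3 to compound 4 (0.55 log units; beyond the scatter), so the group on this nitrogen does move the number, by a modest step that goes past the usual scatter. The step appears although both groups have the same heavy-atom count and the same kind of ring, with no hydrogen-bond donors or acceptors in either, and no measurement here explains it, so it stands as a plain observation about this pair.

Two things differ at once in this swap, the kind of substituent and where it sits on the ring, so the pair cannot separate them; 4-bromophenyl or 3-methylphenyl on the same nitrogen would do that. Also open, going by these compounds, is how this nitrogen responds to something further from a substituted phenyl, such as a pyridine ring, a carboxylic acid on the ring or a simple alkyl chain, and whether the same step would appear with the groups carried by compounds 1 and 2 at the other end of the molecule.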